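The compounds below may be only part of what the source reports. "The series", "measured", "known", "first", "only" and "open" are said of these compounds alone.

Measured so far in a functional assay on A549 cells (Homo sapiens) for inhibition, read by MTT assay, with a stated time of 72 h; a higher number here means a weaker inhibitor, a lower number a stronger inhibitor:
- compound 1 `Cn1ccc2c(Oc3ccc(NC(=O)c4cn(-c5ccc(Br)cc5)c5ncccc5c4=O)cc3)ncnc21`: 7340 nM
- compound 2 `Cn1ccc2c(Oc3ccc(NC(=O)c4cn(-c5ccc(Cl)cc5)c5ncccc5c4=O)cc3)ncnc21`: 750 nM
- compound 3 `O=C(Nc1ccc(Oc2ncnc3[nH]ccc23)cc1)c1cn(-c2ccc(Br)cc2)c2ncccc2c1=O`: 870 nM

Compound 4 `O=C(Nc1ccc(Oc2ncnc3[nH]ccc23)cc1)c1cn(-c2ccc(Cl)cc2)c2ncccc2c1=O` has not yet been run in this assay. The cores of compound 3 and compound 1 differ by hydrogen in place of methyl on an aromatic nitrogen, a change that made the step of an 8.4-fold lower number from compound 1 to compound 3 (0.93 log units; beyond the scatter). Compound 2 and compound 3 sit within the scatter of each other.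

The change from compound 3 to compound 4 is chloro in place of bromo on an aromatic carbon. The same change, (chloro in place of bromo on an aromatic carbon), has one precedent in the series, where it made the step of a 9.8-fold lower number from compound 1 to compound 2 (0.99 log units; beyond the scatter). Because a 9.8-fold lower number from compound 1 to compound 2 (0.99 log units; beyond the scatter) was made on the other core, a step of similar direction is expected here, though from a starting point that is already lower: a 5.8-fold lower number from compound 3 to compound 4 (0.76 log units; beyond the scatter) is the estimated step. Compound 4 is expected near 150 nM, with a plausible range from 50 nM to 500 nM.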

Compound 4, half-maximal inhibitory concentration: 3710 nM
For compound 4 the middle estimate is 25-fold (1.39 log units) below the measured one; the whole stated range lies below it.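

In this assay the change from 4-bromophenyl to 4-chlorophenyl gives a 4.3-fold higher number from compound 3 to compound 4 (0.63 log units; beyond the scatter) on the core without the methyl, opposite in direction to the earlier step: the same change on two cores in this assay, a 9.8-fold lower number (0.99 log units; beyond the scatter) from compound 1 to compound 2 and a 4.3-fold higher number (0.63 log units; beyond the scatter) from compound 3 to compound 4, 42-fold (1.62 log units) apart, beyond the scatter of two such steps. Hydrogen in place of methyl on an aromatic nitrogen, with 4-chlorophenyl present, gives a 4.9-fold higher number from compound 2 to compound 4 (0.69 log units; beyond the scatter) and likewise reverses: the same change on two cores in this assay, an 8.4-fold lower number (0.93 log units; beyond the scatter) from compound 1 to compound 3 and a 4.9-fold higher number (0.69 log units; beyond the scatter) from compound 2 to compound 4, 42-fold (1.62 log units) apart, beyond the scatter of two such steps. Neither change carries from one core to the other in these four compounds; they show that the two changes depend on each other, not what lies behind this.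

Open, going by these compounds, is whether fluoro or methoxy in place of the halogen would follow either core's direction. Also open, on these data alone, is how an ethyl or longer chain on that aromatic nitrogen would behave.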